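Swapping a chloro for a nitro on the aryl ring

The compounds below may be only part of what the source reports. "The series", "measured", "known", "first", "only" and "open" are said of these compounds alone.

Compound 1 `Oc1ccc(/C=N/NC(=S)Nc2nc3ccc(Cl)cc3s2)cc1` and compound 2 `S=C(N/N=C/c1ccc(Cl)cc1)Nc1nc2ccc(Cl)cc2s1` share one core and differ only in a single group on the outer aromatic ring. In a functional assay on the whole organism with Mus musculus as the target, in the maximal electroshock model, with a stated time of 0.5 h (a lower number here means that less compound is needed, a higher number that more compound is needed for the effect), compound 1 gives 100 mg/kg, while compound 2 gives 300 mg/kg, the highest of the two numbers measured. Going by the values given here, the one step recorded, a 3.0-fold higher number from compound 1 to compound 2 (0.48 log units; beyond the scatter), is modest but beyond the scatter.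

Compound 3 `O=[N+]([O-])c1ccc(/C=N/NC(=S)Nc2nc3ccc(Cl)cc3s2)cc1` is the next case, differing from compound 2 by nitro in place of chloro on an aromatic carbon. Among the compounds with values here, no measured step exchanges a chloro for a nitro, so the only guide is the step from compound 1 to compound 2, which shows that changing this one group on the outer ring can shift the dose modestly. Since that step does not involve a nitro, the expectation is a step no larger than the scatter, in either direction, which is what no change at the digits printed from compound 2 to compound 3 (within the scatter) expresses. Compound 3 is therefore expected to give 300 mg/kg in this assay, with a plausible range from 100 mg/kg to 1000 mg/kg.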

Compound 3, minimum effective dose in the Mus musculus assay: 100 mg/kg
The estimate for compound 3 lay 3.0-fold (0.48 log units) above the measured number; low and high end bracket the measured number.
By their numbers in the Mus musculus assay, from the lowest: compounds 1 and 3 (each within the scatter of the next); then compound 2.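

In the Mus musculus assay there is a 3.0-fold lower number from compound 2 to compound 3 (0.48 log units; beyond the scatter), and also no change at the digits printed from compound 1 to compound 3 (within the scatter), so at this place on the outer ring, para to a large group, two different groups, nitro and hydroxy, give the same number, and only the chloro of compound 2 calls for more compound. In a physicochemical assay for lipophilicity, in phosphate buffer, measured as octanol-water partition (on this read-out higher numbers stand for higher lipophilicity and lower numbers for lower lipophilicity), compound 2 gives 5.52, and compound 3 gives 4.68. The change from chloro to nitro that lowers the effective dose therefore also lowers lipophilicity, although a single pair shows only that the two shifts occur together, not that one causes the other: the measured partition coefficient of compound 2, 5.52, and of compound 3, 4.68, a number 0.84 log units lower (beyond the scatter)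

On these data alone, whether lipophilicity tracks the dose more generally remains open, as one pair cannot separate it from anything else that differs between a chloro and a nitro. As far as these compounds go, it is also open how an amine, a methoxy group or a carboxylic acid on the same aromatic carbon would behave in the Mus musculus assay, and whether they would match compounds 1 and 3 or compound 2.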